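The compounds below may be only part of what the source reports. "The series", "measured", "known", "first", "only" and "open" are said of these compounds alone.

Compound 1 (`O=C1C(Nc2ccc(I)cc2)=CC(=O)c2c1nc1n2[C@H]2OC[C@@H](O)[C@H]2OC1`) gives 2150 nM
Compound 2 (`O=C1C=C(Nc2ccccc2F)C(=O)c2c1nc1n2[C@H]2OC[C@@H](O)[C@H]2OC1`) gives 2080 nM

Both values come from a functional assay on MGC-803 cells (Homo sapiens) for inhibition, read by sulforhodamine B assay; on this read-out lower numbers stand for stronger inhibition and higher numbers for weaker inhibition. Compound 2 stands level with compound 1, as their two values lie within the scatter of each other. The next compound, compound 3 (`O=C1C=C(NC2CCCC2)C(=O)c2c1nc1n2[C@H]2OC[C@@H](O)[C@H]2OC1`), has cyclopentyl in place of 2-fluorophenyl on an amine nitrogen. Among the measured compounds shown here, the two measured compounds provide no single-change step, so the data give no direct guide to the size of this one. A modest move toward weaker inhibition in this assay is expected, and a change no larger than the scatter remains possible. The estimated change is small (a 1.4-fold higher number from compound 2 to compound 3 (0.16 log units; within the scatter)) and rests only on this structural difference. For compound 3 the expected value is 3000 nM within an estimated range of 900 nM to 10000 nM on this evidence.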

Compound 3, half-maximal inhibitory concentration: > 8000 nM
Compound 3: a limit, no number; the forecaster's own chance of this, stated with the estimate: 5%; middle value at least 2.6-fold (0.42 log units) from the limit.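

Compound 3 gives > 8000 nM in this assay, which is a limit of the assay and not a number. Among the compounds shown here, this provides the first single-place step, an at least 3.8-fold higher number from compound 2 to compound 3 (0.58 log units; beyond the scatter), showing that the group on this amine nitrogen bears on inhibition and that cyclopentyl does not serve as an equivalent of 2-fluorophenyl here. The size of the step is bounded from one side only: the limit of > 8000 nM in this assay, at which 1 of the 3 values shown sits.

This change alters ring size, aromatic character and the presence of fluorine together, and the compounds shown do not separate these three differences. An unsubstituted phenyl or a cyclohexyl group on the same nitrogen would help to separate them, and would show whether any saturated ring is tolerated at this position.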